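This account rests on a few compounds, and the source may have more. Where it says the series, first, only, none or still open, it means among the compounds named here.

Of the compounds shown here, two with a shared core have been measured so far. Compound 1 `N#Cc1ccc(Cc2cnc(CCc3ccc(-c4ccccc4C(=O)O)cc3)[nH]2)cc1` gives 723 nM in an in vitro functional assay on cells for agonist activity at Bombesin receptor subtype-3 (Mus musculus), read by luminescence and calcium flux; on this read-out lower numbers stand for an effect already at smaller amounts and higher numbers for an effect only at larger amounts of compound. Compound 2 `O=C(O)c1ccccc1-c1ccc(CCc2ncc(-c3ccccc3)[nH]2)cc1` gives 872 nM in this assay, which is the higher of the two numbers, though the gap to compound 1 is small: the step of a 1.2-fold higher number from compound 1 to compound 2 (0.08 log units; within the scatter) lies within the scatter of repeated measurements, so the two compounds cannot be told apart on this evidence.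

Compound 3 `O=C(O)c1ccccc1-c1ccc(CCc2ncc(CC3CCCCCC3)[nH]2)cc1` has not yet been measured. It differs from compound 2 in one place: cycloheptylmethyl in place of phenyl on an aromatic carbon. For the measured compounds named here, no measured step addresses an exchange of this kind; the only step at hand, from a 4-cyanobenzyl group to a phenyl group, moved the number by a 1.2-fold higher number from compound 1 to compound 2 (0.08 log units; within the scatter), which is within the scatter. With one change at that same place producing no clear movement, the expectation for compound 3 is a number close to that of compound 2, the estimated step being a 1.1-fold lower number from compound 2 to compound 3 (0.04 log units; within the scatter). The estimate for compound 3 in this assay is therefore 800 nM, with a plausible range from 250 nM to 2500 nM.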

Compound 3, half-maximal effective concentration: 5.7 nM
Estimate against measurement, compound 3: 140-fold (2.15 log units) above; the whole stated range lies above it.
By their numbers in this assay, from the lowest: compound 3; then compounds 1 and 2 (each within the scatter of the next).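

This position, an aromatic carbon of the five-membered ring with 2 nitrogen, looked indifferent while only phenyl and 4-cyanobenzyl had been compared, but in this assay cycloheptylmethyl brings a 150-fold lower number from compound 2 to compound 3 (2.18 log units; beyond the scatter). The second comparison keeps the saturated chain carbon bound to the ring and exchanges only 4-cyanophenyl for cycloheptyl, giving a 130-fold lower number from compound 1 to compound 3 (2.10 log units; beyond the scatter), so among these compounds the chain carbon alone does not bring the large drop, which appears only when the seven-membered non-aromatic ring is attached to it. Nothing at hand gives a reason for the size of these steps.

On these data alone, it remains open whether the seven-membered ring itself is needed, since these three compounds cannot say whether cyclohexylmethyl, with its six-membered ring, or an open hydrocarbon chain such as n-octyl would give a similarly low number. They also leave unanswered how a hydroxyl group or an amine on the seven-membered ring would change the number, and so how much variation the cycloheptylmethyl group allows at this position.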